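The compounds below may be only part of what the source reports. "The series", "measured", "known", "first", "only" and "open" are said of these compounds alone.

Compound 3 `Cc1cn(C2CC(N=[N+]=[N-])C(COC(=O)NCCCO)O2)c(=O)[nH]c1=O` gives > 48 h in an ADME assay on the whole organism (serum) with Homo sapiens as the target (a higher number here means that the compound lasts longer, a lower number that the compound disappears faster), which is a limit of the assay rather than a number. Compound 1 `Cc1cn(C2CC(N=[N+]=[N-])C(COC(=O)CCCN)O2)c(=O)[nH]c1=O` gives 0.433 h in this assay. Compound 2 `Cc1cn(C2CC(N=[N+]=[N-])C(COC(=O)OCCO)O2)c(=O)[nH]c1=O` gives < 0.0167 h, again only a limit. Compound 3 thus stands at the top of the three, carried there by the steps of an at least 110-fold higher number from compound 1 to compound 3 (2.04 log units; beyond the scatter) and an at least 2800-fold higher number from compound 2 to compound 3 (3.45 log units; beyond the scatter). Compound 4 `Cc1cn(C2CC(N=[N+]=[N-])C(COC(=O)CCCC(=O)O)O2)c(=O)[nH]c1=O` differs from compound 3 by 3-carboxypropyl in place of (3-hydroxypropyl)amino on a carbonyl carbon. A large downward step is expected here, an at least 48-fold lower number from compound 3 to compound 4 (1.68 log units; beyond the scatter), because the change runs opposite to the one behind an at least 110-fold higher number from compound 1 to compound 3 (2.04 log units; beyond the scatter). The outcome for compound 4 is expected to land nearer compound 1 than compound 2. For compound 4 the estimated half-life in this assay is 1 h, between 0.2 h and 5 h.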

Compound 4, half-life: 30 h
For compound 4 the middle estimate is 30-fold (1.48 log units) below the measured one; the measured number lies above the stated range.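

Carboxy in place of amino at the end of the chain moves the number sharply, with a 69-fold higher number from compound 1 to compound 4 (1.84 log units; beyond the scatter), so the chain end on this carbonyl carbon matters even with the oxygen next to a carbonyl group unchanged. 3-carboxypropyl in place of 2-hydroxyethoxy on a carbonyl carbon gives an at least 1700-fold higher number from compound 2 to compound 4 (3.25 log units; beyond the scatter), a step that rests on a limit: the limit of < 0.0167 h in this assay, at which 1 of the 4 values shown sits 3-carboxypropyl in place of (3-hydroxypropyl)amino on a carbonyl carbon gives an at least 1.6-fold lower number from compound 3 to compound 4 (0.20 log units; that floor lies within the scatter), and this step cannot be read further, as it rests on a limit: the limit of > 48 h in this assay, at which 1 of the 4 values shown sits.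

The compounds shown leave open whether a longer chain ending in a carboxylic acid, such as 4-carboxybutyl, would last as long as 3-carboxypropyl does. They also leave open how a plain 3-hydroxypropyl group would behave on this carbonyl carbon.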